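The compounds below may be only part of what the source reports. "The series", "measured", "known", "first", "only" and "open" are said of these compounds alone.

Measured so far in a physicochemical assay for lipophilicity, using the shake flask method, in phosphate buffer, measured as octanol-water partition, at pH 7.4; on this read-out higher numbers stand for higher lipophilicity and lower numbers for lower lipophilicity:
compound 1, `COc1cc(-c2cc(C(=O)O)c3ccccc3n2)ccc1OCC(=O)Nc1ccccc1`, 0.7
compound 2, `COc1cc(-c2cc(C(=O)O)c3ccccc3n2)ccc1OCC(=O)Nc1ccccc1Cl`, 1.6
compound 3, `COc1cc(-c2cc(C(=O)O)c3ccccc3n2)ccc1OCC(=O)NCc1cccnc1`, -0.8

Compound 2 stands highest of the three: the change a number 0.90 log units higher from compound 1 to compound 2 (beyond the scatter) lifts it above compound 1, and the change a number 2.40 log units lower from compound 2 to compound 3 (beyond the scatter) drops far below it. Compound 4, `CCCCCCNC(=O)COc1ccc(-c2cc(C(=O)O)c3ccccc3n2)cc1OC`, differs from compound 2 in one place: hexyl in place of 2-chlorophenyl on an amide-type nitrogen. The step from compound 2 to compound 3 shows that swapping the group on this amide-type nitrogen can move this assay a great deal, but there the entering group carried a hydrogen-bond acceptor; hexyl, like 2-chlorophenyl, carries none. For the measured compounds named here, no measured step swaps a ring for a chain, so the expectation rests on the counted difference alone: compound 4 is expected to show a number 0.10 log units higher from compound 2 to compound 4 (within the scatter), not beyond the scatter, with an estimated value of 1.7, between 1.1 and 2.3.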

Compound 4, distribution coefficient: 1
For compound 4 the middle estimate is 0.70 log units above the measured one; measured number outside the range, below it.
By their numbers in this assay, from the lowest: compound 3; then compounds 1 and 4 (each within the scatter of the next); then compound 2.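

In this assay, replacing the phenyl on this amide-type nitrogen with hexyl gives a number 0.30 log units higher from compound 1 to compound 4 (within the scatter), so here a ring and a chain do not separate. Replacing 2-chlorophenyl with hexyl gives a number 0.60 log units lower from compound 2 to compound 4 (beyond the scatter), a clear step, while the pentyl for pyridin-3-yl change gives a number 1.80 log units higher from compound 3 to compound 4 (beyond the scatter), a larger one. Nothing shown explains why these steps differ.

Still open, from the compounds shown here alone, is how a shorter butyl chain or a longer octyl chain would read. So is what an amine at the end of the hexyl chain would do.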